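This account rests on a few compounds, and the source may have more. Where it says the series, first, only, none or still open, it means among the compounds named here.

Measured compounds in a functional assay on HeLa cells (Homo sapiens) for cytotoxicity, in the presence of a further agent that is not named here; on this read-out lower numbers stand for stronger inhibition and higher numbers for weaker inhibition:
compound 1, `Clc1ccc(-c2cc(-c3cccnc3)nc(-c3ccsc3)c2)o1`, gives > 50000 nM, which is a limit of the assay rather than a number.
compound 2, `Clc1ccc(-c2cc(-c3cccnc3)nc(-c3cccs3)c2)o1`, gives 14600 nM.
compound 3, `Clc1ccc(-c2cc(-c3ccco3)cc(-c3cccs3)n2)cc1`, gives 32700 nM.

Compound 1 thus stands only at a limit in this assay; its position relative to the other two is known only through that limit (the limit of > 50000 nM in this assay, at which 1 of the 3 values shown sits). Within the data shown here, the one step computed, an at least 3.4-fold lower number from compound 1 to compound 2 (0.53 log units; beyond the scatter), concerns the thiophene attachment and not the ring that changes here.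

Compound 4, `Cc1ccc(-c2cc(-c3ccc(Cl)o3)cc(-c3ccsc3)n2)cc1`, is not yet measured. It differs from compound 1 as follows: 4-methylphenyl in place of pyridin-3-yl on an aromatic carbon. Among the measured compounds shown here, no measured pair covers this exchange, so no step gives a direct size or direction; compound 3 carries a different arrangement of the same rings and has no computed step to compound 1, and its value simply sits well inside the measurable range.

For the measured compounds named here, with compound 1 at a limit and no bearing step, the expectation for compound 4 is weak activity near the limit, with wide uncertainty. For compound 4 the estimate in this assay is 40000 nM, with a range from 12000 nM to 100000 nM, corresponding to an expected step of an at least 1.2-fold lower number from compound 1 to compound 4 (0.09 log units; that floor lies within the scatter).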

Compound 4, half-maximal inhibitory concentration: 16200 nM
For compound 4 the middle estimate is 2.5-fold (0.39 log units) above the measured one, and the stated range covers the measured number.
By their numbers in this assay, from the lowest: compounds 2 and 4 (each within the scatter of the next); then compound 3. At a limit, above all of these: compound 1.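

In this assay, the exchange at the position next to the ring nitrogen brings the thiophen-3-yl compound off the assay limit: an at least 3.0-fold lower number from compound 1 to compound 4 (0.48 log units; beyond the scatter). The nitrogen of pyridin-3-yl is therefore not needed for a measurable value with this substitution pattern, as compound 4 carries 4-methylphenyl there and gives 16200 nM. This reading rests on a single pair, and the size of its step is only a floor, since compound 1 stands at a limit rather than at a number: the limit of > 50000 nM in this assay, at which 1 of the 4 values shown sits.

The exchange removes the ring nitrogen and adds the methyl group in one move, so the compounds shown cannot assign the step to either change, and unsubstituted phenyl at this position would be needed to separate the two. Also open, going by these compounds, is how far this position extends beyond these groups, for instance how a 4-aminophenyl or 4-carboxyphenyl group would read in this assay, and whether 4-methylphenyl gives a step of similar size when thiophen-2-yl replaces thiophen-3-yl.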